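A few compounds are considered here, and "the series" means these few. Any claim that something is new, unique, unknown or untested is made for them only; others in the source may bear on it.

The measured compounds:
Compound 1 `Nc1cc(N)c2nc(-c3ccccc3)c(Oc3ccc(Cl)c(Cl)c3)nc2c1`. In a functional assay on NCI-H460 cells (Homo sapiens) for inhibition, read by sulforhodamine B assay, with a stated time of 48 h (a higher number here means that more compound is tolerated, a lower number that less compound is tolerated), compound 1 gives < 100000 nM, which is a limit of the assay and not a number.
Compound 2 `COc1ccc(CNc2nc3cc(N)cc(N)c3nc2-c2ccccc2)cc1OC`. In this assay compound 2 gives < 100000 nM, again a limit rather than a number.
Compound 3 `COc1cc(CNc2nc3cc(N)cc(N)c3nc2-c2ccccc2)cc(OC)c1OC`. In this assay compound 3 gives < 50200 nM, also a limit.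

From the compounds shown here alone, compound 1 therefore stands at a limit only; where it lies within that range is unknown, and it cannot be ordered against compound 2 or compound 3. The change to compound 4 `Nc1cc(N)c2nc(-c3ccccc3)c(Sc3ccc(F)cc3)nc2c1` is (4-fluorophenyl)sulfanyl in place of 3,4-dichlorophenoxy on an aromatic carbon. Among the measured compounds shown here, the one measured step, a step that the two limits leave unreadable from compound 2 to compound 3, is not readable because the limit of < 100000 nM in this assay, at which 2 of the 3 values shown sit, and the limit of < 50200 nM in this assay, at which 1 of the 3 values shown sits, bound both ends, so no measured step gives a direction or size for the change from compound 1 to compound 4. Compound 4 is therefore expected to show 70000 nM, within 15000 nM to 100000 nM, and most probably as a limit again. The estimated step that the limit leaves unreadable from compound 1 to compound 4 is thus expected to be unresolved rather than a readable change.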

Compound 4, concentration lethal to 50% of the cells: < 100000 nM
Compound 4: only a limit was reported; the forecaster's own chance of this, stated with the estimate: 75%; the middle value lies beyond the limit too.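

Compound 1 and compound 4 each stand only at a limit in this assay, so no step can be read between them: the limit of < 100000 nM in this assay, at which 3 of the 4 values shown sit.

The compounds shown leave open where each true value lies, and whether 3,4-dichlorophenoxy and (4-fluorophenyl)sulfanyl differ at all in this read-out.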